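This account rests on a few compounds, and the source may have more. Where it says the series, first, only, none or still open, it means among the compounds named here.

In an assay on lysate for inhibition of phosphatidylcholine:ceramide cholinephosphotransferase 2 (Homo sapiens), read by HPLC, with stated times of 30 min and 2 h (on this read-out lower numbers stand for stronger inhibition and higher numbers for weaker inhibition), compound 1 `O=C(Nc1cccnc1)c1ccccc1OCc1cccc(Cl)c1` gives 1400 nM. Compound 2 `O=C(Nc1cccnc1)c1ccccc1OCc1cc(Cl)ccc1Cl` gives 990 nM. Compound 3 `Cc1ccc(Cl)cc1COc1ccccc1C(=O)Nc1cccnc1` gives 1100 nM.

Compound 3 thus holds the second highest of the three numbers. Its nearest neighbour is compound 2, with a 1.1-fold higher number from compound 2 to compound 3 (0.05 log units; within the scatter), and the furthest is compound 1, with a 1.3-fold lower number from compound 1 to compound 3 (0.10 log units; within the scatter); neither separation exceeds the scatter, so none of the three compounds can be set apart from the others.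

Compound 4 `COc1ccc(Cl)cc1COc1ccccc1C(=O)Nc1cccnc1` differs from compound 3 in one place: methoxy in place of methyl on an aromatic carbon. For the measured compounds named here, two measured steps touch this position. Adding a methyl there, a 1.3-fold lower number from compound 1 to compound 3 (0.10 log units; within the scatter), and swapping chloro for methyl there, a 1.1-fold higher number from compound 2 to compound 3 (0.05 log units; within the scatter), both left the number within the scatter. Going by the values given here, no measured compound carries a methoxy at this position, so the effect of that particular group is not known here. On the steps in hand, a change at this position is expected to produce no step beyond the scatter, giving no change at the digits printed from compound 3 to compound 4 (within the scatter). Compound 4 is therefore estimated at 1100 nM, with a range from 500 nM to 2500 nM.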

Compound 4, half-maximal inhibitory concentration: 670 nM
The estimate for compound 4 lay 1.6-fold (0.22 log units) above the measured number; the measured number falls inside the stated range.
By their numbers in this assay, from the lowest: compounds 4, 2, 3 and 1 (each within the scatter of the next, the first and the last beyond it).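

Methoxy gives the first step at this position that lies beyond the scatter, though only a modest one, measured against hydrogen (as a 2.1-fold lower number from compound 1 to compound 4 (0.32 log units; beyond the scatter)); the methyl and chloro steps from compound 1 had stayed within it. Against those two groups, however, methoxy cannot be set apart, since both steps stay within the scatter (as a 1.6-fold lower number from compound 3 to compound 4 (0.22 log units; within the scatter), and as a 1.5-fold lower number from compound 2 to compound 4 (0.17 log units; within the scatter)), so the series shows only that methoxy differs from hydrogen here. Nothing available explains this result or ties it to any property of the methoxy group.

The compounds shown leave open how an ethoxy group, a hydroxyl or an amine would behave at this position. They also leave open whether the methoxy step would hold if a group other than the chloro group stood para to it.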